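A larger side group on compound 2

The source may hold more compounds than are shown below. What is called first, only, known or untested is meant among the compounds shown, and "the series" means these compounds.

Measured so far in an ADME assay on microsomes from liver (Mus musculus) for metabolic stability, using NADPH, with a stated time of 10 min; on this read-out lower numbers stand for a less stable compound and higher numbers for a more stable compound:
compound 1 (`NCCCCN(C[C@@H]1Cc2nccnc2CN1)[C@H]1CCCc2cccnc21`) gives 73%
compound 2 (`NC(=O)NC/C=C\CN(C[C@H]1Cc2ncccc2CN1)[C@H]1CCCc2cccnc21`) gives 10%

Compound 2 stands lowest of the two measured compounds, and its gap to compound 1 lies beyond the scatter. Among the measured compounds shown here, no step between compounds differing in one place is available, so any forecast here rests on thin ground.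

Compound 3 (`CN(CCCCN(C[C@H]1Cc2ncccc2CN1)[C@H]1CCCc2cccnc21)C1CCOCC1`) has yet to be measured in this assay. Its change from compound 2 is a group of 11 heavy atoms (9 carbon, 1 nitrogen, 1 oxygen; one six-membered non-aromatic ring with 1 hetero atom) in place of a group of 7 heavy atoms (4 carbon, 2 nitrogen, 1 oxygen; no ring), on a saturated chain carbon bound to an amine nitrogen.

Compound 2 at 10% has little room to fall, while compound 1 at 73% shows how much higher a value can lie. A rise beyond the scatter is therefore expected, with an estimated a number 25 percentage points higher from compound 2 to compound 3 (beyond the scatter). The expected value for compound 3 is 35%, within an estimated range of 12% to 65%.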

Compound 3, percent of the compound remaining: 51%
Estimate against measurement, compound 3: 16 percentage points below; measured number inside the range.
By their numbers in this assay, from the lowest: compound 2; then compound 3; then compound 1.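

In this assay, exchanging the side group on a saturated chain carbon bound to an amine nitrogen gives a number 41 percentage points higher from compound 2 to compound 3 (beyond the scatter), which shows that a change in this one place, on a shared core, can shift the read-out by a large amount. Among the compounds shown here, this is the first comparison of its kind in the set, as compound 1 differs from the other two in more than one place. The entering group has a six-membered non-aromatic ring with 1 hetero atom and 0 hydrogen-bond donors, whereas the leaving group has no ring and 2 hydrogen-bond donors, but no measurement available here bears on which of these differences matters.

On these data alone, it remains open whether a morpholine ring or a carboxylic acid in this place would give a value close to that of compound 3. As far as these compounds go, it also remains open whether a step of this size would carry over to the core of compound 1.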